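The source may report more compounds than this note shows. Statements on the series, on what has been measured and on what is new or still open speak of the compounds shown alone.

Of the compounds shown here, three share a common core and have been tested in a functional assay on ileum for inhibition of histamine H1 receptor (Cavia porcellus); a higher number here means a weaker inhibitor, a lower number a stronger inhibitor. Compound 1 `CCCOCCn1c(N2CCCN(C)CC2)nc2ccccc21` gives 16 nM in this assay. Compound 2 `CCCCN1CCCN(c2nc3ccccc3n2CCOCC)CC1` gives 8.4 nM in this assay. Compound 3 `CCCOCCn1c(N2CCN(C)CC2)nc2ccccc21` gives 20 nM in this assay, the highest of the three numbers; the gap to compound 1 lies within the scatter, while compound 2 stands beyond the scatter with its lower number.

The next step leads to compound 4 `CCNCCn1c(N2CCN(C)CC2)nc2ccccc21`, which has not yet been measured. Compared with compound 3 the change is ethylamino in place of propoxy on a saturated chain carbon, two bonds along the chain from an aromatic nitrogen. Within the data shown here, no earlier pair of measured compounds shows this same change, so there is no step to lean on; the propoxy chain is simply replaced by an ethylamino chain, and an expectation can only be tentative.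

For compound 4 a small step toward a higher number, at most modestly beyond the scatter, is expected, a 1.5-fold higher number from compound 3 to compound 4 (0.18 log units; within the scatter). Compound 4 is therefore estimated at 30 nM, most likely between 10 nM and 100 nM.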

Compound 4, half-maximal inhibitory concentration: 290 nM
Estimate against measurement, compound 4: 9.7-fold (0.99 log units) below; measured number above the stated range.
By their numbers in this assay, from the lowest: compounds 2, 1 and 3 (each within the scatter of the next, the first and the last beyond it); then compound 4.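

Putting ethylamino in place of propoxy on a saturated chain carbon, two bonds along the chain from an aromatic nitrogen, gives a 15-fold higher number from compound 3 to compound 4 (1.16 log units; beyond the scatter) in this assay, a large step and well beyond the scatter. So the end of this chain is not a place where any group will do: one swap here moves the number far more than the differences among the earlier compounds. The swap changes several things at once, as ethylamino is the smaller group and carries a hydrogen-bond donor that propoxy lacks, and nothing measured here says which of these matters.

Still open, as far as these compounds go, is whether the nitrogen or the shorter chain drives the step, which a propylamino group in the same place could help to separate. A dimethylamino group, which has no amine hydrogen, would test the role of that hydrogen.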